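This account rests on a few compounds, and the source may have more. Where it says the series, first, only, none or still open, it means among the compounds named here.

Measured in an ADME assay on microsomes from liver (Mus musculus) for metabolic stability, read by LC-MS, using NADPH, with a stated time of 10 min, tested at 0.1 uM; on this read-out higher numbers stand for fast clearance and lower numbers for slow clearance:
- compound 1 `COc1ccc(F)cc1N1C(=O)CSC1c1cccc(C(=O)NCCCCc2ccccc2)c1`: 2250 mL.min-1.g-1
- compound 2 `O=C(NCCCCc1ccccc1)c1cccc(C2SCC(=O)N2c2cccc(F)c2)c1`: 2740 mL.min-1.g-1

In this assay, compound 2 lies within the scatter of compound 1, so the two cannot be ordered. Compound 3 `O=C(NCCCCc1ccccc1)c1cccc(C2SCC(=O)N2c2ccccc2F)c1` differs from compound 2 in one place: 2-fluorophenyl in place of 3-fluorophenyl on an amide-type nitrogen in a ring. This puts 2-fluorophenyl in place of 3-fluorophenyl on an amide-type nitrogen in a ring. Among the measured compounds shown here, only one measured step bears on this change, a 1.2-fold higher number from compound 1 to compound 2 (0.09 log units; within the scatter), which also alters a substituent on an aromatic carbon and stays within the scatter. No step beyond the scatter is therefore expected, and the estimated step is a 1.1-fold lower number from compound 2 to compound 3 (0.04 log units; within the scatter). Compound 3 is expected at 2500 mL.min-1.g-1, with an estimated range of 1300 mL.min-1.g-1 to 4600 mL.min-1.g-1.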

Compound 3, intrinsic clearance in microsomes: 2010 mL.min-1.g-1
Compound 3: middle estimate off by 1.2-fold (0.09 log units), on the high side; the measured number falls inside the stated range.
By their numbers in this assay, from the lowest: compounds 3, 1 and 2 (each within the scatter of the next).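

Putting 2-fluorophenyl in place of 3-fluorophenyl on the amide-type nitrogen in the ring gives a 1.4-fold lower number from compound 2 to compound 3 (0.13 log units; within the scatter) in this assay and so adds a direct read of the fluorine's place on this phenyl, which does not separate the two compounds. Putting 2-fluorophenyl in place of 5-fluoro-2-methoxyphenyl gives a 1.1-fold lower number from compound 1 to compound 3 (0.05 log units; within the scatter) and so leaves all three groups at this nitrogen within the scatter of one another.

From the compounds shown here alone, whether an amine or a carboxylic acid on this phenyl would give a step beyond the scatter stays open. Nothing available accounts for how close these numbers lie.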